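Imidazole Chain Variation and Bombesin Receptor Subtype-3 Agonism

The source may report more compounds than this note shows. Statements on the series, on what has been measured and on what is new or still open speak of the compounds shown alone.

Within the data shown here, compound 2 `CC(C)(C)CCc1cnc(CCc2ccc(-c3ccccc3C(=O)O)cc2)[nH]1` gives the lowest of the two numbers so far in an in vitro functional assay on cells for agonist activity at Bombesin receptor subtype-3 (Homo sapiens), read by luminescence and calcium flux (on this read-out lower numbers stand for an effect already at smaller amounts and higher numbers for an effect only at larger amounts of compound), with 39 nM. Compound 1 `CC(C)(C)c1cnc(CCc2ccc(-c3ccccc3C(=O)O)cc2)[nH]1` gives 4330 nM in this assay, and the step of a 110-fold lower number from compound 1 to compound 2 (2.05 log units; beyond the scatter) arose from a 3,3-dimethylbutyl in place of tert-butyl on an aromatic carbon. Compound 3 `Cc1ccc(Cc2cnc(CCc3ccc(-c4ccccc4C(=O)O)cc3)[nH]2)cc1` differs from compound 2 by 4-methylphenyl in place of neopentyl on a saturated chain carbon bound to an aromatic carbon. Among the measured compounds shown here, no measured step shows the same change; the one step available, from compound 1 to compound 2, concerns the length of this same substituent and shows that changes at this position move the number strongly. From the compounds shown here alone, because a 110-fold lower number from compound 1 to compound 2 (2.05 log units; beyond the scatter) is large, a sizable shift is plausible here too, though its direction is unknown, and a moderate rise is expected as the likelier outcome, a 3.1-fold higher number from compound 2 to compound 3 (0.49 log units; beyond the scatter). Compound 3 is therefore expected to give 120 nM in this assay, within a range from 15 nM to 900 nM.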

Compound 3, half-maximal effective concentration: 2660 nM
For compound 3 the middle estimate is 22-fold (1.35 log units) below the measured one; measured number outside the range, above it.
By their numbers in this assay, from the lowest: compound 2; then compounds 3 and 1 (each within the scatter of the next).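

In this assay the exchange of neopentyl for 4-methylphenyl gave a 68-fold higher number from compound 2 to compound 3 (1.83 log units; beyond the scatter) and so removed nearly all of the gain that the 3,3-dimethylbutyl group had brought. The other new step, a 1.6-fold lower number from compound 1 to compound 3 (0.21 log units; within the scatter), places the 4-methylbenzyl and tert-butyl groups level with each other, so among these three compounds only the 3,3-dimethylbutyl group in compound 2 gives the low number, and the larger substituent count in compound 3 did not bring it. Nothing measured here accounts for the difference between these groups.

From the compounds shown here alone, it remains open whether the low number depends on the saturated chain or on its branched end, which a straight butyl chain or a 2-cyclohexylethyl group in this place would help to separate. Going by these compounds, whether an amine at the end of the chain would be tolerated also remains open.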